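This account rests on a few compounds, and the source may have more. Where it says the series, first, only, none or still open, it means among the compounds named here.

In a functional assay on A549 cells (Homo sapiens) for antiproliferative activity, read by MTT assay, with a stated time of 72 h (on this read-out higher numbers stand for weaker inhibition and lower numbers for stronger inhibition), compound 3 `COc1ccc(-c2c(C(=O)c3cc(OC)c(OC)c(OC)c3)sc3ccccc23)cc1C` gives > 10000 nM, which is a limit of the assay and not a number. Compound 2 `COc1ccccc1-c1c(C(=O)c2cc(OC)c(OC)c(OC)c2)sc2ccccc12` gives > 10000 nM, also a limit. Compound 1 `COc1cc(C(=O)c2sc3ccccc3c2-c2ccc(F)cc2)cc(OC)c1OC` alone gives a number, 3200 nM. Compound 4 `COc1cc(C(=O)c2sc3ccccc3c2Nc2ccc(C)cc2)cc(OC)c1OC` carries (4-methylphenyl)amino in place of 4-methoxy-3-methylphenyl on an aromatic carbon. Two measured changes at this place replaced 4-fluorophenyl, giving an at least 3.1-fold higher number from compound 1 to compound 2 (0.49 log units; beyond the scatter) and an at least 3.1-fold higher number from compound 1 to compound 3 (0.49 log units; beyond the scatter), both beyond the scatter. Neither involves the entering group, so they show only that this place matters. With compound 3 at the limit of > 10000 nM in this assay, at which 2 of the 3 values shown sit, a modest move towards stronger inhibition is expected, and the estimated step is an at least 2.5-fold lower number from compound 3 to compound 4 (0.39 log units; beyond the scatter). Compound 4 is estimated at 4000 nM, with an expected range of 400 nM to 15000 nM.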

Compound 4, half-maximal inhibitory concentration: 2600 nM
For compound 4 the middle estimate is 1.5-fold (0.19 log units) above the measured one; the range from low to high includes it.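

In this assay, the place on the shared core also accepts a group linked through nitrogen, and (4-methylphenyl)amino restores a measurable value, with an at least 3.8-fold lower number from compound 3 to compound 4 (0.58 log units; beyond the scatter) and an at least 3.8-fold lower number from compound 2 to compound 4 (0.58 log units; beyond the scatter). The step from 4-fluorophenyl is a 1.2-fold lower number from compound 1 to compound 4 (0.09 log units; within the scatter), so the two groups cannot be told apart here. Compound 2 and compound 3 stand at a limit of the assay and not at a number, so those two steps have only a lower bound: the limit of > 10000 nM in this assay, at which 2 of the 4 values shown sit.

The compounds shown do not separate the effect of the nitrogen link from that of the ring it carries. On these data alone, how a plain amine or a (4-fluorophenyl)amino group would behave at this place remains open.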